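Swapping chloro for methoxy on a weakly active compound

This account rests on a few compounds, and the source may have more. Where it says the series, first, only, none or still open, it means among the compounds named here.

Measured in a functional assay on A549 cells (Homo sapiens) for antiproliferative activity, read by MTT assay, with a stated time of 48 h; on this read-out lower numbers stand for stronger inhibition and higher numbers for weaker inhibition:
- Compound 1 `Fc1ccc2[nH]c(-c3cn(-c4ccccc4)nc3-c3ccc(Cl)cc3)nc2c1`: 4610 nM
- Compound 2 `O=C(OCc1ccccc1)c1ccc2[nH]c(-c3cn(-c4ccccc4)nc3-c3ccc(Cl)cc3)nc2c1`: 7730 nM

Going by the values given here, only two numbers exist so far, and they cannot be told apart: the record shows a 1.7-fold higher number from compound 1 to compound 2 (0.22 log units; within the scatter). Among the compounds with values here, compound 2 therefore stands level with the only other measured compound, and neither can be ranked above the other.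

Compound 3 `COc1ccc(-c2nn(-c3ccccc3)cc2-c2nc3cc(C(=O)OCc4ccccc4)ccc3[nH]2)cc1` keeps the benzyloxycarbonyl group of compound 2 and changes one other group: methoxy in place of chloro on an aromatic carbon. In short, this is methoxy in place of chloro on an aromatic carbon, turning 4-chlorophenyl into 4-methoxyphenyl.

Within the data shown here, no measured pair tests this change directly. Among the measured compounds shown here, the one available step, from fluoro to benzyloxycarbonyl, concerns a different group and is a 1.7-fold higher number from compound 1 to compound 2 (0.22 log units; within the scatter) already seen, so it offers only a rough sense of how far these numbers move. With so little evidence, no shift beyond the scatter is expected in this assay, and no direction can be favoured.

For compound 3 the estimated value is 7000 nM, with an expected range from 3000 nM to 16000 nM. This estimate means an expected 1.1-fold lower number from compound 2 to compound 3 (0.04 log units; within the scatter).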

Compound 3, half-maximal inhibitory concentration: 11900 nM
Compound 3: middle estimate off by 1.7-fold (0.23 log units), on the low side; the range from low to high includes it.
By their numbers in this assay, from the lowest: compounds 1, 2 and 3 (each within the scatter of the next, the first and the last beyond it).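

Going by these compounds alone, the change from 4-chlorophenyl to 4-methoxyphenyl gives the first reading at this position in this assay: a 1.5-fold higher number from compound 2 to compound 3 (0.19 log units; within the scatter). Within the data shown here, the earlier step changed a different place on the shared core, so this is the first sign that this aromatic carbon, para to a large group, can take either group with no difference that can be read in this assay, at least with the benzyloxycarbonyl group in place. Methoxy brings two heavy atoms and one hydrogen-bond acceptor where chloro brought one heavy atom and no acceptor, yet the two compounds cannot be told apart, and no other measurement here helps to explain this result.

The compounds shown leave open whether a hydroxyl, an amine or a carboxylic acid on this carbon would give a number beyond the scatter of those of compound 2 and compound 3. They also leave open whether methoxy and chloro would still read alike with fluoro in place of benzyloxycarbonyl, as in compound 1.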